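A Second Chloro Group and Its Expected Effect on Cytotoxicity

This account rests on a few compounds, and the source may have more. Where it says the series, first, only, none or still open, it means among the compounds named here.

Compound 1 `Cn1c(SCc2ccccc2)nnc1-c1cc([N+](=O)[O-])cc([N+](=O)[O-])c1` and compound 2 `Cn1c(SCc2ccc(Cl)cc2)nnc1-c1cc([N+](=O)[O-])cc([N+](=O)[O-])c1` share one core and differ only by chloro in place of hydrogen on an aromatic carbon. In an ADME assay on HepG2 cells (Homo sapiens) for cytotoxicity, with a stated time of 48 h (a higher number here means a weaker inhibitor, a lower number a stronger inhibitor), compound 1 gives only a limit of the assay, > 30000 nM. Compound 2 likewise gives only a limit, > 30000 nM. The step between them, a step that the two limits leave unreadable from compound 1 to compound 2, is therefore not readable. Compound 3 `O=[N+]([O-])c1cc(-c2nnc(SCc3ccc(Cl)cc3)n2Cc2ccccc2)cc(C(F)(F)F)c1` also gives only a limit, > 30000 nM. The difference between its core and that of compound 1 is not broken down here. Compound 4 `O=[N+]([O-])c1cc(-c2nnc(SCc3ccc(Cl)c(Cl)c3)n2Cc2ccccc2)cc(C(F)(F)F)c1` differs from compound 3 by chloro in place of hydrogen on an aromatic carbon. This is the same kind of change as that from compound 1 to compound 2, though here the new chloro sits ortho to a chloro group and meta to a large group, rather than para to a large group. Because (the limit of > 30000 nM in this assay, at which 3 of the 3 values shown sit), the expected step is a step that the limit leaves unreadable from compound 3 to compound 4. Compound 4 is estimated at 50000 nM.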

Compound 4, half-maximal inhibitory concentration: > 30000 nM
Compound 4 ended at the assay's limit; the forecaster's own chance of this, stated with the estimate: 85%; the middle value does not contradict the limit.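

Going by these compounds alone, compound 3 and compound 4 both give only a limit of the assay, so no step between them can be read. The compounds shown leave open how strongly any of them inhibits in this assay and whether a chloro group changes that at all.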